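Nitrooxy pyrazolines: aryl swap at the saturated ring carbon

A few compounds are considered here, and "the series" means these few. Any claim that something is new, unique, unknown or untested is made for them only; others in the source may bear on it.

Two measured members define the range so far. Compound 1 `COc1ccc(C2CC(c3ccc(OC)c(OC)c3)=NN2C(=O)C(C)Br)c(OC)c1` gives 63% in a functional assay on the whole organism (strain albino) for inhibition, with Rattus norvegicus as the target, read by paw edema, with stated times of 30 min and 2 h, at a dose of 100 mg/kg by the oral route; on this read-out higher numbers stand for more inhibition at the one dose given (going by the name of the read-out) and lower numbers for less inhibition. Compound 2 `COc1ccc(C2=NN(C(=O)C(C)O[N+](=O)[O-])C(c3ccco3)C2)cc1OC` gives 39% in this assay, the lower of the two numbers, and the gap to compound 1 lies beyond the scatter; the two compounds differ in more than one place, so the gap cannot be tied to a single change.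

Compound 3 `COc1ccc(C2CC(c3ccc(OC)c(OC)c3)=NN2C(=O)C(C)O[N+](=O)[O-])c(OC)c1` is the unmeasured member. It differs from compound 2 by a single replacement (2,4-dimethoxyphenyl in place of furan-2-yl on a saturated ring carbon). Among the measured compounds shown here, no step between measured compounds shows this change on its own, so its size has to be guessed. For the measured compounds named here, the only anchor is compound 1, which carries the same 2,4-dimethoxyphenyl on a saturated ring carbon and gives 63% in this assay. The step of a number 16 percentage points higher from compound 2 to compound 3 (beyond the scatter) is therefore expected to be upward and beyond the scatter. Compound 3 is expected to give 55% in this assay, with a range of 40% to 70%.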

Compound 3, a percentage reported as inhibition, in the whole organism at one dose (the size of the read-out at that dose, not a potency): 61%
Compound 3: middle estimate off by 6 percentage points, on the low side; low and high end bracket the measured number.
By their numbers in this assay, from the lowest: compound 2; then compounds 3 and 1 (each within the scatter of the next).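

In this assay, 2,4-dimethoxyphenyl in place of furan-2-yl on a saturated ring carbon now reads on its own as a number 22 percentage points higher from compound 2 to compound 3 (beyond the scatter) and so is a real single-place change at this position, with nitrooxy held constant on the chain. With 2,4-dimethoxyphenyl held constant, nitrooxy in place of bromo on a saturated chain carbon bound to a carbonyl carbon gives a number 2 percentage points lower from compound 1 to compound 3 (within the scatter) and so does not separate these two groups at the one dose given. The compounds shown come with no measurement that explains either step.

From the compounds shown here alone, whether the ring-carbon step is due to the methoxy groups or to the ring itself stays open, as a plain phenyl with no methoxy groups at this position would be needed to tell. Going by these compounds, a chain carrying an amine in place of nitrooxy or bromo also remains open.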